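Compound 3 to compound 4: methoxy in place of bromo

The compounds below may be only part of what the source reports. "The series", "measured", "known", "first", "only" and "open" are said of these compounds alone.

Measured in a functional assay on KB cells (Homo sapiens) for antiproliferative activity, read by sulforhodamine B assay, with a stated time of 3 days; on this read-out lower numbers stand for an effect already at smaller amounts and higher numbers for an effect only at larger amounts of compound:
- compound 1 `CCC1=C(O)c2c(oc(-c3ccc(CC)cc3)cc2=O)C(CC)(CC)C1=O`: 21.9 uM
- compound 2 `CCOc1ccc(-c2cc(=O)c3c(o2)C(CC)(CC)C(=O)C(CC)=C3O)cc1`: > 52.4 uM (a limit)
- compound 3 `CCC1=C(O)c2c(oc(-c3ccc(CBr)cc3)cc2=O)C(CC)(CC)C1=O`: > 46.5 uM (a limit)

Compound 3 stands at a limit, > 46.5 uM, and has no number of its own. Compound 4 `CCC1=C(O)c2c(oc(-c3ccc(COC)cc3)cc2=O)C(CC)(CC)C1=O` differs from it at one place: methoxy in place of bromo on a saturated chain carbon bound to an aromatic carbon.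

For the measured compounds named here, two measured steps bear on this change. The first, an at least 2.1-fold higher number from compound 1 to compound 3 (0.32 log units; beyond the scatter), is a change at the same place. The second, an at least 2.3-fold higher number from compound 1 to compound 2 (0.37 log units; beyond the scatter), brings in an ethoxy group on an aromatic carbon. Both are modest at minimum and both lead to higher numbers. The step that the two limits leave unreadable from compound 2 to compound 3 gives no guidance. Compound 4 is therefore expected to stay nearer the limits than compound 1 in this assay, with no step beyond the scatter expected from the limit of compound 3. The expected step is an at least 1.2-fold lower number from compound 3 to compound 4 (0.08 log units; that floor lies within the scatter). The estimate for compound 4 is 38 uM, with an expected range of 17 uM to 80 uM.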

Compound 4, concentration for half-maximal effect: > 52.4 uM
Compound 4 ended at the assay's limit (the forecaster's own chance of this, stated with the estimate: 45%); middle value at least 1.3-fold (0.13 log units) away from the limit.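

In this assay the change from 4-(bromomethyl)phenyl to 4-(methoxymethyl)phenyl yields no readable number, and compound 4 stands at a limit: the limit of > 52.4 uM in this assay, at which 2 of the 4 values shown sit.
Against the methyl of compound 1, the methoxy on the saturated chain carbon gives an at least 2.3-fold higher number from compound 1 to compound 4 (0.37 log units; beyond the scatter), so at this place the shift to a higher number is not confined to bromo but appears with a second, different group.
The steps among compound 2, compound 3 and compound 4 cannot be read, and all three stand at limits.

Going by these compounds, the true size of the shift from compound 1 remains open, as does any order among the three limit compounds.
Also open, on these data alone, is how an amine or a carboxylic acid at this place would read, and whether a longer chain such as propyl would stay near compound 1 at 21.9 uM.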